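The compounds below may be only part of what the source reports. "The series", "measured", "known", "first", "only" and "open" are said of these compounds alone.

Working notes on the aryloxypropyl series, shared core as in compound 1 `NC1=NC2(CCSCC2)N(OCCCOc2cccc(Cl)c2)C(N)=N1`. In a functional assay on HepG2 cells (Homo sapiens) for antiproliferative activity, read by MTT assay, with a stated time of 72 h (on this read-out lower numbers stand for stronger inhibition and higher numbers for weaker inhibition), compound 1 gives 90 nM. Compound 2 `NC1=NC2(CCSCC2)N(OCCCOc2cccc(Cl)c2Cl)C(N)=N1`, carrying a second chloro, gives 50 nM; the step is a 1.8-fold lower number from compound 1 to compound 2 (0.26 log units; within the scatter). Compound 3 `NC1=NC2(CCSCC2)N(OCCCOc2ccccc2Br)C(N)=N1`, with the 2-bromophenyl, gives 90 nM; from compound 1 the step is no change at the digits printed from compound 1 to compound 3 (within the scatter), and the step of a 1.8-fold higher number from compound 2 to compound 3 (0.26 log units; within the scatter) is likewise within the scatter. Compound 3 therefore stands level with compound 1 at the digits printed, the two together the highest numbers of the three, with compound 2 nearest below but not separated beyond the scatter.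

Compound 4 `NC1=NC2(CCSCC2)N(OCCCOc2ccc(Cl)c(Cl)c2)C(N)=N1` differs from compound 3 by 3,4-dichlorophenyl in place of 2-bromophenyl on an oxygen on a saturated carbon. The bearing steps are those among compounds 1, 2 and 3: a single chloro added gave a 1.8-fold lower number from compound 1 to compound 2 (0.26 log units; within the scatter), and exchanging one halophenyl for another gave no change at the digits printed from compound 1 to compound 3 (within the scatter). All three lie within the scatter, so for compound 4 no step beyond the scatter is expected in this assay; the expected step is a 1.4-fold lower number from compound 3 to compound 4 (0.14 log units; within the scatter), leaning slightly toward the dichlorophenyl compound 2 because of 50 nM. Compound 4 is thus estimated at 65 nM, with a range of 30 nM to 140 nM.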

Compound 4, half-maximal inhibitory concentration: 70 nM
For compound 4 the middle estimate is 1.1-fold (0.03 log units) below the measured one; the measured number falls inside the stated range.
By their numbers in this assay, from the lowest: compounds 2, 4, 1 and 3 (each within the scatter of the next).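

At this place, on an oxygen on a saturated carbon, this assay gives a 1.3-fold lower number from compound 3 to compound 4 (0.11 log units; within the scatter) for the exchange of 2-bromophenyl for 3,4-dichlorophenyl and a 1.4-fold higher number from compound 2 to compound 4 (0.15 log units; within the scatter) for the exchange of 2,3-dichlorophenyl for 3,4-dichlorophenyl, so a second dichlorophenyl pattern is now covered and neither exchange separates the compounds. Adding a chloro to the ring of compound 1 now has two readings, a 1.8-fold lower number from compound 1 to compound 2 (0.26 log units; within the scatter) and a 1.3-fold lower number from compound 1 to compound 4 (0.11 log units; within the scatter) and both stay within the scatter, so the four halophenyl compounds form one level group in this assay. Nothing on hand offers an explanation for this level picture.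

The compounds shown carry only chloro or bromo on the phenyl ring. As far as these compounds go, how an amine or a carboxylic acid on that ring, or a longer chain in place of the propyl chain, would read in this assay remains open.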